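A Second Fluorine on the Amide Aryl of Compound 3

This account rests on a few compounds, and the source may have more. Where it says the series, first, only, none or still open, it means among the compounds named here.

Four compounds share one core and differ only in the group on the carbonyl carbon. Compound 1 `O=C(C1CCC1)N1CCCC[C@@H]1c1nc(-c2cccc(F)c2)no1` carries a cyclobutyl there and in an in vitro functional assay on HEK293-A cells for positive allosteric modulation of metabotropic glutamate receptor 5 (Homo sapiens), read by fluorescence and calcium flux, with a stated time of 140 s (a higher number here means that more compound is needed for the effect, a lower number that less compound is needed), compound 1 gives 600 nM; 650 nM (2 entries); its repeat entries the several entries of compound 1 in this assay, 600 nM; 650 nM (2 entries) show how closely duplicates agree. Compound 2 `O=C(C1CCCCC1)N1CCCC[C@@H]1c1nc(-c2cccc(F)c2)no1` gives 3500 nM in this assay. Among the measured compounds shown here, compound 3 `O=C(c1ccc(F)cc1)N1CCCC[C@@H]1c1nc(-c2cccc(F)c2)no1`, with a 4-fluorophenyl on the carbonyl carbon, gives 23000 nM in this assay, the highest of the two single numbers; the only other single number lies lower: a 6.6-fold higher number from compound 2 to compound 3 (0.82 log units; beyond the scatter). Compound 4 `O=C(c1ccc(F)cc1F)N1CCCC[C@@H]1c1nc(-c2cccc(F)c2)no1` differs from compound 3 by fluoro in place of hydrogen on an aromatic carbon. For the measured compounds named here, no measured step tests such an added fluoro; the one measured step replaces the whole group on the carbonyl carbon instead. A step within the scatter is therefore expected for compound 4, a 1.2-fold lower number from compound 3 to compound 4 (0.06 log units; within the scatter). Compound 4 is estimated at 20000 nM in this assay, within 6000 nM to 60000 nM.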

Compound 4, half-maximal effective concentration: 2900 nM
Estimate against measurement, compound 4: 6.9-fold (0.84 log units) above; the whole stated range lies above it.
By their numbers in this assay, from the lowest: compounds 4 and 2 (each within the scatter of the next); then compound 3.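

Adding one fluoro on an aromatic carbon, ortho to a large group, gives a 7.9-fold lower number from compound 3 to compound 4 (0.90 log units; beyond the scatter) in this assay, so the high number of compound 3 does not hold for every aryl group on the carbonyl carbon. The 2,4-difluorophenyl group also draws level with cyclohexyl: a 1.2-fold lower number from compound 2 to compound 4 (0.08 log units; within the scatter). Repeat entries agree far more closely than the step from compound 3 to compound 4: the several entries of compound 1 in this assay, 600 nM; 650 nM (2 entries)

As far as these compounds go, whether the drop needs fluoro itself remains open. A chloro or a methyl on the same carbon would test that.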